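A few compounds are considered here, and "the series" means these few. Any claim that something is new, unique, unknown or untested is made for them only; others in the source may bear on it.

Measured so far:
compound 1, `COC(C)(C)[C@@H](O)C(=O)N1[C@H](C(=O)NCc2cc(Cl)ccc2-n2cnnn2)C[C@@H]2C[C@@H]21` — 1000 nM
compound 2, `CC(C)(C)[C@@H](O)C(=O)N1OCC[C@H]1C(=O)NCc1cc(Cl)ccc1-n1cnnn1` — 1600 nM
compound 3, `CC(C)(C)[C@@H](O)C(=O)N1C[C@@H]2C[C@@H]2[C@H]1C(=O)NCc1cc(Cl)ccc1-n1cnnn1` — 570 nM

In a functional assay on a cell-free system (plasma, Homo sapiens), with a stated time of 3 min (a higher number here means a weaker inhibitor, a lower number a stronger inhibitor), compound 1 gives 1000 nM. Its gaps to compound 2 and to compound 3 both lie within the usual scatter of repeated measurements, so the three numbers cannot be told apart on this evidence, and none of the compounds stands out.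

Compound 4, `CC(C)(C)C[C@@H](O)C(=O)N1[C@H](C(=O)NCc2cc(Cl)ccc2-n2cnnn2)C[C@@H]2C[C@@H]21`, is not yet measured. It differs from compound 1 in one place: neopentyl in place of 1-methoxy-1-methylethyl on a saturated chain carbon bound to a carbonyl carbon and an oxygen on a saturated carbon. Going by the values given here, the change removes a hydrogen-bond acceptor and keeps the same count of heavy atoms, and no pair among the measured compounds shows this change.

For compound 4 in this assay the expected number is 800 nM, within 300 nM to 2500 nM, a step from a 1.3-fold lower number from compound 1 to compound 4 (0.10 log units; within the scatter) expected to stay within the scatter.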

Compound 4, half-maximal inhibitory concentration: 570 nM
For compound 4 the middle estimate is 1.4-fold (0.15 log units) above the measured one; low and high end bracket the measured number.
By their numbers in this assay, from the lowest: compounds 3, 4, 1 and 2 (each within the scatter of the next, the first and the last beyond it).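

In this assay, going by these compounds alone, the swap to neopentyl in place of 1-methoxy-1-methylethyl gives a 1.8-fold lower number from compound 1 to compound 4 (0.24 log units; within the scatter) and is the first one-place comparison at this position. On the core of compound 1, then, losing the hydrogen-bond acceptor while keeping the same count of heavy atoms leaves a number that cannot be told apart from the original. No measurement shown here offers an explanation for this result. Still open, as far as these compounds go, is whether an amine, a carboxylic acid or a longer chain at this position would give a step beyond the scatter.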